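Cyano in place of methoxy on a saturated ring carbon

The compounds below may be only part of what the source reports. "The series", "measured", "known", "first", "only" and "open" are said of these compounds alone.

In a physicochemical assay for solubility, in phosphate buffer, measured as kinetic solubility, with a stated time of 24 h, at pH 7.4 (a higher number here means a more soluble compound, a lower number a less soluble compound), compound 3 `COC1CCN(c2ccc(CN(CC(C)C)S(=O)(=O)Cc3ccccc3)cc2)CC1` gives <= 1000 nM, which is a limit and not a number. Compound 1 `CC(C)CN(Cc1ccc(N2CCN(S(C)(=O)=O)CC2)cc1)S(=O)(=O)Cc1ccccc1` gives <= 1000 nM, also a limit. Compound 2 `CC(C)CN(Cc1ccc(N2CCN(C)CC2)cc1)S(=O)(=O)Cc1ccccc1` gives 60000 nM. Compound 4 `CC(C)CN(Cc1ccc(N2CCC(C#N)CC2)cc1)S(=O)(=O)Cc1ccccc1` carries cyano in place of methoxy on a saturated ring carbon, three ring bonds from the ring nitrogen: cyano in place of methoxy on a saturated ring carbon. Going by the values given here, no measured step makes this exchange. The nearest steps, an at least 60-fold lower number from compound 2 to compound 3 (1.77 log units; beyond the scatter) and an at least 60-fold higher number from compound 1 to compound 2 (1.77 log units; beyond the scatter), are both large, but both involve the 4-methylpiperazin-1-yl group of compound 2, which compound 4 does not carry. The step that the two limits leave unreadable from compound 1 to compound 3 gives no readable size. No change beyond the scatter is therefore expected in this assay, and the estimated step is a number no lower from compound 3 to compound 4 (the limit leaves the size open). Compound 4 is estimated at 1000 nM, with an expected range from 400 nM to 4000 nM.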

Compound 4, solubility: <= 1000 nM
Compound 4: a limit, no number; the forecaster's own chance of this, stated with the estimate: 65%; the middle value sits exactly at the limit.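

In this assay compound 4 gives <= 1000 nM, a limit and not a number. With 4-cyanopiperidin-1-yl in place of 4-methylpiperazin-1-yl there is an at least 60-fold lower number from compound 2 to compound 4 (1.77 log units; beyond the scatter), so compound 2 still stands alone among the four compounds with a value clear of the limit. The steps from compound 1 and compound 3 to compound 4 cannot be read, because these values all rest on the same limit: the limit of <= 1000 nM in this assay, at which 3 of the 4 values shown sit.

As far as these compounds go, how far compound 1, compound 3 and compound 4 lie under that limit stays open. So does whether an amine or a carboxylic acid on this saturated ring carbon would give a readable number.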